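A few compounds are considered here, and "the series" means these few. Any claim that something is new, unique, unknown or untested is made for them only; others in the source may bear on it.

Compound 1 `Oc1cccc(-c2cc(-c3ccncc3)nc(-c3ccccc3Cl)c2)c1` belongs to the same family, but in a functional assay on T47D cells (Homo sapiens) for cytotoxicity, read by CCK-8 assay and cell counting, with a stated time of 2 days (on this read-out higher numbers stand for weaker inhibition and lower numbers for stronger inhibition), the entry for compound 1 reads "not determined" (no result reported), so no result was reported for it. For the measured compounds named here, compound 2 `Oc1cccc(-c2cc(-c3ccsc3)nc(-c3ccccc3Cl)c2)c1` is the only member with a number: in this assay compound 2 gives 2440 nM, and since the other entry carries no value, compound 2 stands alone as the single point of reference. Compound 3 `Oc1cccc(-c2cc(-c3ccccc3)nc(-c3ccccc3Cl)c2)c1` differs from compound 2 in one place, namely (phenyl in place of thiophen-3-yl on an aromatic carbon). Going by the values given here, no step between two measured compounds is available, so nothing in the data shows how such a ring exchange moves the half-maximal inhibitory concentration here. The step of a 1.0-fold higher number from compound 2 to compound 3 (0.01 log units; within the scatter) is therefore expected to be small, within the usual scatter and in no clear direction. On that basis compound 3 is estimated to give 2500 nM in this assay, with a range from 900 nM to 7000 nM.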

Compound 3, half-maximal inhibitory concentration: 2920 nM
For compound 3 the middle estimate is 1.2-fold (0.07 log units) below the measured one, and the stated range covers the measured number.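

For the compounds shown here, the first step that can be read at this position, on an aromatic carbon next to the ring nitrogen, is a 1.2-fold higher number from compound 2 to compound 3 (0.08 log units; within the scatter) in this assay and comes with the exchange of thiophen-3-yl for phenyl. At this place, then, a five-membered aromatic ring with 1 hetero atom and a six-membered aromatic ring of carbon only cannot be told apart in this read-out, and the sulfur of thiophen-3-yl shows no separate contribution in this one pair. Nothing measured alongside these compounds offers an explanation for this result.

The compounds shown leave open whether this tolerance extends beyond these two aromatic rings. An amine, a carboxylic acid or a longer chain such as n-butyl at this carbon could behave quite differently, and a single pair cannot tell.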